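This account rests on a few compounds, and the source may have more. Where it says the series, first, only, none or still open, it means among the compounds named here.

Working notes on the series. Among the compounds with values here, compound 1 `COc1cc(NC(C)CCCNC(=O)Nc2ccc(Br)cc2)c2ncccc2c1` is the reference here: in a functional assay on CCRF-CEM cells (Homo sapiens) for inhibition, read by MTT assay, with a stated time of 72 h (on this read-out lower numbers stand for stronger inhibition and higher numbers for weaker inhibition), compound 1 gives 23000 nM, which is the lowest number among the three compounds measured so far. Its nearest neighbour is compound 3 `COc1cc(NC(C)CCCNC(=O)Nc2cccc(O)c2)c2ncccc2c1`, which in this assay gives 32000 nM; the step of a 1.4-fold higher number from compound 1 to compound 3 (0.14 log units; within the scatter) stays within the scatter. The furthest is compound 2 `COc1cc(NC(C)CCCNC(=O)NNC(=O)Nc2ccc(F)cc2)c2ncccc2c1`, which in this assay gives 118000 nM; the step of a 5.1-fold higher number from compound 1 to compound 2 (0.71 log units; beyond the scatter) lies beyond the scatter. Between the two, a 3.7-fold lower number from compound 2 to compound 3 (0.57 log units; beyond the scatter).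

Compound 4 `COc1cc(NC(C)CCCNC(=O)NNC(=O)Nc2cccc(Cl)c2)c2ncccc2c1` has not yet been measured. It differs from compound 1 as follows: ((3-chlorophenyl)carbamoyl)amino in place of 4-bromophenyl on an amide-type nitrogen. Within the data shown here, two measured steps bear on this. The step of a 5.1-fold higher number from compound 1 to compound 2 (0.71 log units; beyond the scatter) inserts the same carbamoylamino spacer with a different halogen on the ring, and the step of a 1.4-fold higher number from compound 1 to compound 3 (0.14 log units; within the scatter) changes the substitution of the phenyl ring alone without moving the number beyond the scatter. The spacer insertion therefore carries the weight, and in this assay a modest step towards a higher number is expected for compound 4.

The estimate for compound 4 in this assay is 90000 nM, with a range from 35000 nM to 230000 nM, which means an expected step of a 3.9-fold higher number from compound 1 to compound 4 (0.59 log units; beyond the scatter).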

Compound 4, half-maximal inhibitory concentration: 81000 nM
Compound 4: middle estimate off by 1.1-fold (0.05 log units), on the high side; the range from low to high includes it.
By their numbers in this assay, from the lowest: compounds 1 and 3 (each within the scatter of the next); then compounds 4 and 2 (each within the scatter of the next).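

In this assay, the ((3-chlorophenyl)carbamoyl)amino group gives a 3.5-fold higher number from compound 1 to compound 4 (0.55 log units; beyond the scatter) and a 2.5-fold higher number from compound 3 to compound 4 (0.40 log units; beyond the scatter), so the move away from compounds 1 and 3 no longer rests on compound 2 alone: both compounds with the carbamoylamino spacer on the amide-type nitrogen stand apart from both compounds without it. New here is a 1.5-fold lower number from compound 2 to compound 4 (0.16 log units; within the scatter): 3-chlorophenyl in place of 4-fluorophenyl changes both the halogen and its named ring location without leaving the scatter, which matches a 1.4-fold higher number from compound 1 to compound 3 (0.14 log units; within the scatter) among the compounds without the spacer, so across these four compounds only the spacer separates the numbers. No measurement is at hand that would explain why the spacer goes with higher numbers in this cell assay.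

Compounds 2 and 4 change the halogen and its ring location together, so the separate contribution of each remains unresolved, as does the outcome for an unsubstituted phenyl on the spacer. Also open, going by these compounds, is whether a terminal amine, a carboxylic acid or a longer alkyl chain in place of the aryl group would give a number lower than that of compound 1.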